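The source may hold more compounds than are shown below. What is called first, only, known or untested is meant among the compounds shown, and "the series" means these compounds.

Working notes on the series, all read in a functional assay on MDA-MB-231 cells (Homo sapiens) for inhibition, read by MTT assay, with a stated time of 72 h (on this read-out lower numbers stand for stronger inhibition and higher numbers for weaker inhibition), throughout. Compound 3 `CC(C)(C)OC(=O)NCCOc1ccc(Cl)cc1C(=O)NCC(=O)Nc1ccc2c(c1)S(=O)(=O)C=C2` gives 2080 nM as the lowest of the two numbers in hand. Compound 2 `CC(C)[C@H](NC(=O)c1cc(Cl)ccc1OCCN)C(=O)Nc1ccc2c(c1)S(=O)(=O)C=C2` gives 5950 nM as the other number, and the gap between these two values lies beyond the scatter. Compound 1 `CC(C)C[C@H](NC(=O)c1cc(Cl)ccc1OCCNC(=O)OC(C)(C)C)C(=O)Nc1ccc([N+](=O)[O-])cc1Cl` reads > 10000 nM in this assay and this is a limit of the assay, not a number.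

The next compound to read is compound 4 `NCCOc1ccc(Cl)cc1C(=O)NCC(=O)Nc1ccc2c(c1)S(=O)(=O)C=C2` which has hydrogen in place of tert-butoxycarbonyl on an amine nitrogen and is otherwise the same as compound 3. For the measured compounds named here, no measured pair shows this change alone, so any expectation is indirect. Compound 2 carries the same 2-aminoethyl chain that compound 4 will have, and compound 2 gives 5950 nM as a number higher than that of compound 3. Compound 1 goes against any simple reading, since it keeps the tert-butoxycarbonyl and still reads the limit > 10000 nM in this series.

A small step towards weaker inhibition is expected, estimated as a 1.9-fold higher number from compound 3 to compound 4 (0.28 log units; within the scatter) on this evidence. In this assay the estimated value for compound 4 is 4000 nM with a range from 1300 nM to 10000 nM expected for repeat measurements.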

Compound 4, half-maximal inhibitory concentration: 6370 nM
The estimate for compound 4 lay 1.6-fold (0.20 log units) below the measured number, and the stated range covers the measured number.
By their numbers in this assay, from the lowest: compound 3; then compounds 2 and 4 (each within the scatter of the next). At a limit, above all of these: compound 1.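

In this assay, for the compounds shown here, hydrogen in place of tert-butoxycarbonyl on the amine nitrogen gives a 3.1-fold higher number from compound 3 to compound 4 (0.49 log units; beyond the scatter) as the first direct reading of this change, which the earlier compounds could only suggest indirectly, and within this pair the tert-butoxycarbonyl form is the stronger inhibitor. With the 2-aminoethyl chain held constant, hydrogen in place of isopropyl on the saturated chain carbon bound to an amide-type nitrogen and a carbonyl carbon gives a 1.1-fold higher number from compound 2 to compound 4 (0.03 log units; within the scatter) in this assay and so leaves no readable change at that carbon on this chain. Nothing measured here accounts for either step.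

Going by these compounds, whether the tert-butoxycarbonyl step holds with isopropyl on that chain carbon stays open, as does the reading of other groups on the amine nitrogen, such as an acetyl group, or of a chain longer than 2-aminoethyl. Compound 1 reads > 10000 nM as a limit of the assay and differs from the others in more than one place, so it enters no comparison.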